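The source may hold more compounds than are shown below. What is called first, only, known or untested is meant among the compounds shown, and "the series" means these compounds.

Measured in a functional assay on SW1573 cells (Homo sapiens) for inhibition, read by sulforhodamine B assay, with a stated time of 48 h; a higher number here means a weaker inhibitor of growth, a lower number a stronger inhibitor of growth:
compound 1, `COC(=O)[C@@]1(C)CC[C@@H]2C3=C1CC[C@@H](C)[C@]3(C)C[C@@H]1c3ccccc3N[C@H]21`, gives 30000 nM
compound 2, `COC(=O)[C@@]1(C)CC[C@@H]2C3=C1CC[C@@H](C)[C@]3(C)Cc1c2[nH]c2ccccc12`, gives 8300 nM
compound 3, `COC(=O)[C@@]1(C)CC[C@@H]2C3=C1CC[C@@H](C)[C@]3(C)Cc1c2[nH]c2ccc(C)cc12`, gives 15000 nM

Compound 1 and compound 2 share a large part of the molecule, but the difference between the two cores is not broken down here. In this assay the gap from compound 1 to compound 2 lies beyond the scatter, while the gap from compound 1 to compound 3 lies within it.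

The change from compound 2 to compound 3 is methyl in place of hydrogen on an aromatic carbon and gives a 1.8-fold higher number from compound 2 to compound 3 (0.26 log units; within the scatter).

Compound 4, `COC(=O)[C@@]1(C)CC[C@@H]2C3=C1CC[C@@H](C)[C@]3(C)C[C@@H]1c3cccc(C)c3N[C@H]21`, is not yet measured; it differs from compound 1 by methyl in place of hydrogen on an aromatic carbon. The places are not the same: in compound 3 the methyl is meta to a fused ring and para to a fused ring, in compound 4 ortho to a fused ring and meta to a fused ring, so this is the same kind of change, not the same change.

For compound 4 the expected step in this assay is a 1.5-fold higher number from compound 1 to compound 4 (0.18 log units; within the scatter), resting on a 1.8-fold higher number from compound 2 to compound 3 (0.26 log units; within the scatter), a single step within the scatter and on a different core, so the footing is loose. For compound 4 the estimate in this assay is 45000 nM, between 20000 nM and 100000 nM.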

Compound 4, concentration for 50% growth inhibition: 31000 nM
Estimate against measurement, compound 4: 1.5-fold (0.16 log units) above; the measured number falls inside the stated range.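

In this assay, methyl in place of hydrogen on an aromatic carbon gives a 1.0-fold higher number from compound 1 to compound 4 (0.01 log units; within the scatter). Set beside the earlier step, the two cores do not separate for this change: the same change on two cores in this assay, a 1.8-fold higher number (0.26 log units; within the scatter) from compound 2 to compound 3 and a 1.0-fold higher number (0.01 log units; within the scatter) from compound 1 to compound 4, 1.7-fold (0.24 log units) apart, within the scatter of two such steps. Among the compounds shown here, this shows only that on both cores the methyl stays within the scatter; it does not show that the change carries over at one and the same place, as the places differ between the two cores, and neither step is large enough to show a real effect that could be carried from one core to the other.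

The compounds shown leave open whether another group on the aromatic ring, such as chlorine, a methoxy group or an amine, would move the number beyond the scatter on either core. Also open, from the compounds shown here alone, are the methyl at a matching place on both cores and the replacement of the methyl ester by a carboxylic acid or an amide.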